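Swapping Ethynyl for Hydroxymethyl on a Carbonyl Carbon

This account rests on a few compounds, and the source may have more. Where it says the series, first, only, none or still open, it means among the compounds named here.

In a functional assay on MGC-803 cells (Homo sapiens) for inhibition, read by MTT assay, with a stated time of 48 h (on this read-out lower numbers stand for stronger inhibition and higher numbers for weaker inhibition), compound 3 (`C#CC(=O)N(Cc1ccc(OC)c(O)c1)c1cc(OC)c(OC)c(OC)c1`) gives 170 nM. Compound 2 (`COc1ccc(CN(C(=O)C(C)Br)c2cc(OC)c(OC)c(OC)c2)cc1O`) gives 120 nM, and the gap to the ethynyl amide is small: a 1.4-fold higher number from compound 2 to compound 3 (0.15 log units; within the scatter). Compound 1 (`CCCCC(=O)N(Cc1ccc(OC)c(O)c1)c1cc(OC)c(OC)c(OC)c1`) gives 66 nM, which sets compound 3 apart from it by a modest margin: a 2.6-fold higher number from compound 1 to compound 3 (0.41 log units; beyond the scatter).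

Among the measured compounds shown here, the next structure, compound 4 (`COc1ccc(CN(C(=O)CO)c2cc(OC)c(OC)c(OC)c2)cc1O`), keeps the shared core and changes only one group, with hydroxymethyl in place of ethynyl on a carbonyl carbon.

For the measured compounds named here, three measured steps bear on this change, since all of them exchange the group at this same place. Besides the two above, there is a 1.8-fold higher number from compound 1 to compound 2 (0.26 log units; within the scatter). The largest of the three is the modest one, and the other two stay within the scatter. Butyl, 1-bromoethyl and ethynyl therefore leave the number in a narrow band, but none of these steps introduces hydroxymethyl, so the data give no firm direction for it. A step beyond the scatter is not expected, with only a slight lean towards a higher number. The expected step is a 1.2-fold higher number from compound 3 to compound 4 (0.07 log units; within the scatter). Compound 4 is estimated at 200 nM, with an expected range from 70 nM to 600 nM.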

Compound 4, half-maximal inhibitory concentration: 160 nM
Beside the measured number, compound 4's estimate is 1.3-fold (0.10 log units) above it; the range from low to high includes it.
By their numbers in this assay, from the lowest: compounds 1, 2, 4 and 3 (each within the scatter of the next, the first and the last beyond it).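

In this assay, the exchange of ethynyl for hydroxymethyl on a carbonyl carbon adds a hydrogen-bond donor and a hydrogen-bond acceptor, yet the number does not separate the two groups (a 1.1-fold lower number from compound 3 to compound 4 (0.03 log units; within the scatter)). Hydroxymethyl is likewise not separated from 1-bromoethyl (a 1.3-fold higher number from compound 2 to compound 4 (0.12 log units; within the scatter)), whereas the comparison with the butyl amide shows a modest gap beyond the scatter (a 2.4-fold higher number from compound 1 to compound 4 (0.38 log units; beyond the scatter)), similar to the one already seen for ethynyl (a 2.6-fold higher number from compound 1 to compound 3 (0.41 log units; beyond the scatter)), so the four groups tried at this place still span only a narrow band, and compound 2 is itself within the scatter of compound 1 (a 1.8-fold higher number from compound 1 to compound 2 (0.26 log units; within the scatter)). Nothing available explains why this position tolerates such different groups, or why compound 1 stands apart from compound 3 and compound 4.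

The compounds shown leave open whether an amine, a carboxylic acid or a chain longer than butyl on this carbonyl carbon would stay in the same band. They also leave open whether a methoxymethyl group would behave as hydroxymethyl does, which would show whether the free hydroxy group matters here at all.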